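Replacing bromo with hydrogen on the phenyl series

The source may hold more compounds than are shown below. What is called first, only, known or untested is meant among the compounds shown, and "the series" means these compounds.

Measured in a functional assay on A549 cells (Homo sapiens) for inhibition, read by MTT assay, with a stated time of 72 h; on this read-out higher numbers stand for weaker inhibition and lower numbers for stronger inhibition:
- Compound 1 `COc1ccc(-c2nnc(SCCCN3CCN(c4nc5ccccc5s4)CC3)o2)cc1` gives 90300 nM
- Compound 2 `O=[N+]([O-])c1ccc(-c2nnc(SCCCN3CCN(c4nc5ccccc5s4)CC3)o2)cc1` gives 96600 nM
- Compound 3 `Brc1ccc(-c2nnc(SCCCN3CCN(c4nc5ccccc5s4)CC3)o2)cc1` gives 62500 nM

The three compounds share one core and differ only in the group on the aromatic ring. In this assay, compound 3 at 62500 nM lies within the scatter of both other compounds, so the set shows no clear order. Next comes compound 4 `c1ccc(-c2nnc(SCCCN3CCN(c4nc5ccccc5s4)CC3)o2)cc1`, which differs from compound 3 by hydrogen in place of bromo on an aromatic carbon. The same change can be read as 4-bromophenyl to phenyl.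

Among the measured compounds shown here, three measured steps bear on it, all exchanges at this same place. They are a 1.1-fold higher number from compound 1 to compound 2 (0.03 log units; within the scatter), a 1.4-fold lower number from compound 1 to compound 3 (0.16 log units; within the scatter) and a 1.5-fold lower number from compound 2 to compound 3 (0.19 log units; within the scatter). Nitro, methoxy and bromo thus gave values within the scatter of each other, but no measured compound carries hydrogen at this place. On that evidence, no step beyond the scatter is expected in this assay, and no direction is firmly indicated. An expected 1.3-fold higher number from compound 3 to compound 4 (0.11 log units; within the scatter) would stay inside that scatter. For compound 4 the estimated value is 80000 nM, with an expected range of 45000 nM to 135000 nM.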

Compound 4, half-maximal inhibitory concentration: 257000 nM
For compound 4 the middle estimate is 3.2-fold (0.51 log units) below the measured one; measured number above the stated range.
By their numbers in this assay, from the lowest: compounds 3, 1 and 2 (each within the scatter of the next); then compound 4.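

In this assay, among the compounds shown here, the exchange for hydrogen is the first change at this place on the aromatic ring to carry a step beyond the scatter: there is a 4.1-fold higher number from compound 3 to compound 4 (0.61 log units; beyond the scatter) and likewise a 2.8-fold higher number from compound 1 to compound 4 (0.45 log units; beyond the scatter) and a 2.7-fold higher number from compound 2 to compound 4 (0.42 log units; beyond the scatter). Methoxy, nitro and bromo gave values within the scatter of one another, yet each of these compounds gives a lower number, and so stronger inhibition, than compound 4; among these four compounds, having one of the three groups at this place matters more than which of them it is, and no compound goes against that reading. Nothing measured here accounts for this gap.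

Going by these compounds, it remains open whether another group at this place, such as a hydroxyl, an amine or a carboxylic acid, would stand with the three substituted compounds or with compound 4. Also open, on these data alone, is whether the same exchange of bromo for hydrogen would give a step of similar size on a different core or with a longer chain in place of the present linker.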